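The source may report more compounds than this note shows. Statements on the series, on what has been measured and on what is new or still open speak of the compounds shown alone.

In a functional assay on K562 cells (Homo sapiens) for antiproliferative activity, read by MTT assay (on this read-out lower numbers stand for stronger inhibition and higher numbers for weaker inhibition), three compounds with a shared core have been measured: compound 1 `O=C(CCCCCNC(=S)N/N=C(\c1ccccc1)c1ccccn1)NO` gives 2140 nM, compound 2 `Cc1ccc(/C(=N/NC(=S)NCCCCCC(=O)NO)c2ccccc2)cc1` gives 4340 nM, and compound 3 `O=C(CCCCCNC(=S)N/N=C(\c1ccccc1)c1ccc([N+](=O)[O-])cc1)NO` gives 2890 nM. Compound 3 stands within the scatter of both others, as the steps show: a 1.4-fold higher number from compound 1 to compound 3 (0.13 log units; within the scatter) and a 1.5-fold lower number from compound 2 to compound 3 (0.18 log units; within the scatter). Compound 4 `COc1ccccc1/C(=N/NC(=S)NCCCCCC(=O)NO)c1ccccc1` differs from compound 3 by one change, 2-methoxyphenyl in place of 4-nitrophenyl on a carbon with a double bond to nitrogen. The only step beyond the scatter among these compounds is modest: a 2.0-fold higher number from compound 1 to compound 2 (0.31 log units; beyond the scatter). Within the data shown here, no measured compound carries 2-methoxyphenyl, so the expectation remains uncertain. The expected change is no shift beyond the scatter, with an estimated step of a 1.0-fold higher number from compound 3 to compound 4 (0.02 log units; within the scatter). For compound 4 the estimated value is 3000 nM, with an expected range of 1500 nM to 6000 nM.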

Compound 4, half-maximal inhibitory concentration: 3560 nM
For compound 4 the middle estimate is 1.2-fold (0.07 log units) below the measured one; the range from low to high includes it.
By their numbers in this assay, from the lowest: compounds 1, 3, 4 and 2 (each within the scatter of the next, the first and the last beyond it).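

In this assay, 2-methoxyphenyl on this carbon with a double bond to nitrogen stays within the scatter of all three earlier groups, whether set against 4-nitrophenyl (a 1.2-fold higher number from compound 3 to compound 4 (0.09 log units; within the scatter)), 4-methylphenyl (a 1.2-fold lower number from compound 2 to compound 4 (0.09 log units; within the scatter)) or pyridin-2-yl (a 1.7-fold higher number from compound 1 to compound 4 (0.22 log units; within the scatter)). A group with its substituent named at the 2-position therefore does not widen the span already set by compound 1 and compound 2. Nothing available explains why these groups read so alike. Still open, going by these compounds, is whether a carboxylic acid or an amine on this aromatic ring would move the number beyond the scatter.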